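Tertiary amine on the side chain of the shared core

This account rests on a few compounds, and the source may have more. Where it says the series, first, only, none or still open, it means among the compounds named here.

Three compounds share the core of compound 1 `CCCCCCCCCCc1ccc(-c2noc(CN)n2)cc1` and differ only in the amine-bearing chain. In an assay on HeLa cells for inhibition of sphingosine-1-phosphate transporter SPNS2 (Mus musculus), read by LC-MS, tested at 2 uM (on this read-out lower numbers stand for less inhibition and higher numbers for more inhibition at the one concentration tested (going by the name of the read-out)), compound 1 gives 62%, compound 2 `CCCCCCCCCCc1ccc(-c2noc(CCCCN)n2)cc1` gives 55% and compound 3 `CCCCCCCCCCc1ccc(-c2noc(CCCNC)n2)cc1` gives 45%. Among the three, the number for compound 3 is the smallest; the two steps that lead to it read a number 10 percentage points lower from compound 2 to compound 3 (within the scatter) and a number 17 percentage points lower from compound 1 to compound 3 (beyond the scatter).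

Compound 4 `CCCCCCCCCCc1ccc(-c2noc(CCCN(C)C)n2)cc1` carries the change (methyl in place of hydrogen on an amine nitrogen). The nearest measured steps are a number 10 percentage points lower from compound 2 to compound 3 (within the scatter), which also adds a methyl on the amine nitrogen, and a number 7 percentage points lower from compound 1 to compound 2 (within the scatter), which lengthens the chain; both are small, and only the combined step a number 17 percentage points lower from compound 1 to compound 3 (beyond the scatter) reaches beyond the scatter. Each added alkyl group has so far come with a slightly lower number, so a further small drop or no step beyond the scatter is expected for compound 4 in this assay, estimated as a number 7 percentage points lower from compound 3 to compound 4 (within the scatter). Compound 4 is therefore expected to give about 38%, in the range 24% to 52%.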

Compound 4, a percentage reported as inhibition, at one concentration (the size of the read-out at that concentration, not a potency): 8%
For compound 4 the middle estimate is 30 percentage points above the measured one, outside the stated range (below it).
By their numbers in this assay, from the lowest: compound 4; then compounds 3, 2 and 1 (each within the scatter of the next, the first and the last beyond it).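

On the amine nitrogen of this side chain, methyl in place of hydrogen proves to be a large change once the nitrogen already carries one methyl: in this assay the step reads a number 37 percentage points lower from compound 3 to compound 4 (beyond the scatter), against the step within the scatter of a number 10 percentage points lower from compound 2 to compound 3 (within the scatter). The gaps to the two primary amines are larger, at a number 47 percentage points lower from compound 2 to compound 4 (beyond the scatter) and a number 54 percentage points lower from compound 1 to compound 4 (beyond the scatter), so the dimethylamino compound stands apart from the three amines that keep a hydrogen on nitrogen. No measurement at hand accounts for this drop.

Open, going by these compounds, is whether the low number belongs to dimethylamino alone or extends to other tertiary amines, such as a diethylamino group on the same chain. A dimethylamino group on the shorter chain of compound 1 would show whether the drop holds at another chain length.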